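Side-Chain Swap on an Amide-Linked Ester in Mice

A few compounds are considered here, and "the series" means these few. Any claim that something is new, unique, unknown or untested is made for them only; others in the source may bear on it.

Compound 2 `NC(=O)C[C@H](NC(=O)CN(c1ncnc2c1ncn2C1CCCCO1)C1CC1)C(=O)OCc1ccccc1` stands lowest of the two compounds measured in a functional assay on the whole organism (Tail, strain ICR) with Mus musculus as the target, in the tail flick test, with a stated time of 30 min, at a dose of 25 umol/kg by the oral route (a higher number here means a stronger effect of the compound at the dose given, a lower number a weaker effect), where compound 2 gives 34.5%. Among the measured compounds shown here, its only neighbour is compound 1 `O=C(CN(c1ncnc2c1ncn2C1CCCCO1)C1CC1)NCC(=O)OCc1ccccc1`, which in this assay gives 55.7%. For the measured compounds named here, the single measured step, a number 21.2 percentage points lower from compound 1 to compound 2 (beyond the scatter), came with carbamoylmethyl in place of hydrogen on a saturated chain carbon bound to an amide-type nitrogen and a carbonyl carbon. Compound 3 `CC(C)(C)OC(=O)NCCCC[C@H](NC(=O)CN(c1ncnc2c1ncn2C1CCCCO1)C1CC1)C(=O)OCc1ccccc1` is not yet measured and differs from compound 2 by 3-((tert-butoxycarbonyl)amino)propyl in place of carbamoyl on a saturated chain carbon, two bonds along the chain from an amide-type nitrogen and a carbonyl carbon. Going by the values given here, only the step from compound 1 to compound 2 bears on this change, and it was modest. Because a number 21.2 percentage points lower from compound 1 to compound 2 (beyond the scatter) already pointed downward when a group was placed on that chain carbon, a larger group there is expected to give a similar or somewhat lower number. This step is estimated at a number 6.5 percentage points lower from compound 2 to compound 3 (within the scatter). Compound 3 is therefore expected to give 28%, within a range from 8% to 50%.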

Compound 3, a percentage reported as activity, at one dose (the size of the read-out at that dose, not a potency): 18.3%
Estimate against measurement, compound 3: 9.7 percentage points above; the measured number falls inside the stated range.
By their numbers in this assay, from the lowest: compound 3; then compound 2; then compound 1.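

In this assay, exchanging carbamoyl for 3-((tert-butoxycarbonyl)amino)propyl on this chain carbon gives a number 16.2 percentage points lower from compound 2 to compound 3 (beyond the scatter), showing that the position can lose further effect beyond that already seen with carbamoylmethyl. Read against the hydrogen, 4-((tert-butoxycarbonyl)amino)butyl gives a number 37.4 percentage points lower from compound 1 to compound 3 (beyond the scatter), the largest step in the set, and across these three compounds the number falls as the group on that carbon gains heavy atoms, with none going against this order. Nothing available explains this fall in the whole-animal read-out.

The compounds shown leave open whether the chain or its tert-butoxycarbonyl cap carries the loss. A free primary amine at the end of the butyl chain, or an unsubstituted butyl chain, would separate the two.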